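From Ethynyl to Iodo on the Shared Core

The source may hold more compounds than are shown below. What is called first, only, known or untested is meant among the compounds shown, and "the series" means these compounds.

Measured in a functional assay on HL-60 cells (Homo sapiens) for antiproliferative activity, read by XTT assay, with a stated time of 72 h; on this read-out higher numbers stand for weaker inhibition and lower numbers for stronger inhibition:
compound 1 (`CNc1ncnc2c1c(-c1ccsc1)cn2[C@@H]1O[C@H](CO)[C@@H](O)[C@H]1O`) gives > 20000 nM
compound 2 (`CNc1ncnc2c1c(-c1ccccc1)cn2[C@@H]1O[C@H](CO)[C@@H](O)[C@H]1O`) gives > 20000 nM
compound 3 (`C#Cc1cn([C@@H]2O[C@H](CO)[C@@H](O)[C@H]2O)c2ncnc(NC)c12`) gives 9060 nM

The value of compound 1 is a limit. The value of compound 2 is also a limit. Compound 3 alone has a number, and the other two stand at the limit of > 20000 nM in this assay, at which 2 of the 3 values shown sit.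

Compound 4 (`CNc1ncnc2c1c(I)cn2[C@@H]1O[C@H](CO)[C@@H](O)[C@H]1O`) carries iodo in place of ethynyl on an aromatic carbon.

Within the data shown here, two measured steps touch this carbon: an at least 2.2-fold lower number from compound 1 to compound 3 (0.34 log units; beyond the scatter) and an at least 2.2-fold lower number from compound 2 to compound 3 (0.34 log units; beyond the scatter). Neither involves iodo, so in this assay no step beyond the scatter is expected, though a drift toward higher numbers is possible. The expected change is a 1.3-fold higher number from compound 3 to compound 4 (0.12 log units; within the scatter). For compound 4 the estimated value is 12000 nM (expected range 4000 nM to 30000 nM).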

Compound 4, half-maximal inhibitory concentration: > 20000 nM
Compound 4 was reported as a limit (the forecaster's own chance of this, stated with the estimate: 35%); at least 1.6-fold (0.22 log units) between middle value and limit.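

With an at least 2.2-fold higher number from compound 3 to compound 4 (0.34 log units; beyond the scatter) in this assay, iodo does not retain the activity seen with ethynyl at this aromatic carbon, so the earlier loss is not confined to the two groups containing rings. Among the four compounds, only ethynyl now gives a number, while the other three groups share one limit: the limit of > 20000 nM in this assay, at which 3 of the 4 values shown sit.

The steps from compound 1 and from compound 2 to compound 4 join two limits and cannot be read. From the compounds shown here alone, whether a nitrile, an amine or a longer alkyne chain at this carbon would match ethynyl remains open.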